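Aryl substitution on the ether-linked chain of the shared core

The compounds below may be only part of what the source reports. "The series", "measured", "known", "first", "only" and "open" are said of these compounds alone.

Among the compounds with values here, compound 1 `COc1ccccc1N1CCN(CCCCOc2ccc(C(=O)Nc3ccccc3OCCCC(=O)O)cc2)CC1` is the weaker of the two compounds measured so far in an assay on isolated protein for inhibition of steroid 5-alpha-reductase (Rattus norvegicus) (a lower number here means a stronger inhibitor, a higher number a weaker inhibitor), where compound 1 gives 43000 nM. The other measured compound, compound 2 `COc1ccccc1N1CCN(CCC(Oc2ccc(C(=O)Nc3ccccc3OCCCC(=O)O)cc2)c2ccc(CC(C)C)cc2)CC1`, gives 39 nM in this assay; the gap between these two values lies well beyond the scatter of repeated measurements. Compound 3 `COc1ccccc1N1CCN(CCCC(Oc2ccc(C(=O)Nc3ccccc3OCCCC(=O)O)cc2)c2ccccc2)CC1` is the next member of the series awaiting measurement. The change from compound 1 to compound 3 is phenyl in place of hydrogen on a saturated chain carbon bound to an oxygen on an aromatic ring and a saturated chain carbon. Within the data shown here, no measured pair differs only in this way, so the size of the step must be estimated. Given the contrast between compound 1 and compound 2 in this assay, a marked move toward stronger inhibition is expected for compound 3, a step of a 110-fold lower number from compound 1 to compound 3 (2.03 log units; beyond the scatter). Compound 3 is accordingly estimated at 400 nM in this assay, with a range from 70 nM to 2500 nM.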

Compound 3, half-maximal inhibitory concentration: 750 nM
For compound 3 the middle estimate is 1.9-fold (0.27 log units) below the measured one; the range from low to high includes it.
By their numbers in this assay, from the lowest: compound 2; then compound 3; then compound 1.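

Phenyl in place of hydrogen on a saturated chain carbon bound to an oxygen on an aromatic ring and a saturated chain carbon is now seen as a single change on the shared core, and in this assay it gives a 57-fold lower number from compound 1 to compound 3 (1.76 log units; beyond the scatter) as a large step toward stronger inhibition. Within the data shown here, the earlier contrast between compound 1 and compound 2 involved more than one change, so it could tie no step to one group. This position therefore accepts a phenyl group, and that group alone accounts for a large part of the range seen so far in the series, though no available measurement explains the step.

Open, as far as these compounds go, is whether a methyl or a cyclohexyl group on the same carbon gives a step of similar size. Also open, from the compounds shown here alone, is what an isobutyl group on the phenyl of compound 3 adds with the chain otherwise unchanged.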